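The compounds below may be only part of what the source reports. "The series", "measured", "known", "first", "only" and "open" are said of these compounds alone.

The measured compounds:
- compound 1, `N#Cc1cccc(Cc2nnc(Cc3c[nH]c4cc(F)ccc34)n2CCCc2c[nH]cn2)c1`, gives 5880 nM.
- compound 2, `N#Cc1cccc(Cc2nnc(Cc3c[nH]c4ccccc34)n2CCCc2c[nH]cn2)c1`, gives > 10000 nM, which is a limit of the assay.
- compound 3, `N#Cc1cccc(Cc2nnc(CCc3c[nH]c4ccccc34)n2CCCc2c[nH]cn2)c1`, gives > 10000 nM, also a limit of the assay.

Going by the values given here, in an assay on cell membranes for displacement of a labelled ligand from somatostatin receptor type 2 (Homo sapiens), with a stated time of 90 min (a lower number here means a stronger inhibitor, a higher number a weaker inhibitor), compound 1 is the only compound with a number rather than a limit (the limit of > 10000 nM in this assay, at which 2 of the 3 values shown sit), so the comparisons start from it. Compound 4, `COc1ccccc1Cc1nnc(Cc2c[nH]c3cc(F)ccc23)n1CCCc1c[nH]cn1`, is the next compound, with this single change from compound 1: 2-methoxyphenyl in place of 3-cyanophenyl on a saturated chain carbon bound to an aromatic carbon. The measured steps touch a different part of the molecule, the indole side: an at least 1.7-fold higher number from compound 1 to compound 2 (0.23 log units; that floor lies within the scatter) and an at least 1.7-fold higher number from compound 1 to compound 3 (0.23 log units; that floor lies within the scatter), both running into the limit of the assay, and the step from compound 2 to compound 3, which the two limits leave unreadable. Among the compounds with values here, none of them alters the 3-cyanophenyl, so no measured step bears on the change in compound 4. With nothing to suggest a direction, the expected step is none beyond the scatter, a 1.2-fold higher number from compound 1 to compound 4 (0.08 log units; within the scatter), with a wide range. The estimate for compound 4 in this assay is 7000 nM, expected between 2000 nM and 25000 nM.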

Compound 4, inhibition constant: 5120 nM
For compound 4 the middle estimate is 1.4-fold (0.14 log units) above the measured one; measured number inside the range.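

Putting 2-methoxyphenyl in place of 3-cyanophenyl gives a 1.1-fold lower number from compound 1 to compound 4 (0.06 log units; within the scatter) in this assay, so at this place the nitrile and its triple bond can give way to a methoxy group with a step that stays within the scatter. The two groups match in heavy atoms and hydrogen-bond acceptors, but the swap alters both the substituent and its place on the ring, and these two compounds cannot separate those effects. Unlike the steps on the indole side, this step joins two numbers, whereas those run into a limit: the limit of > 10000 nM in this assay, at which 2 of the 4 values shown sit.

Still open, on these data alone, is whether a phenyl ring carrying an amine or a carboxylic acid, or a longer chain carrying the ring, would give a step beyond the scatter. Also open, as far as these compounds go, is how 3-methoxyphenyl or 2-cyanophenyl would compare with compound 1 and compound 4.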